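The compounds below may be only part of what the source reports. "The series", "measured", "known", "first", "only" and "open" are said of these compounds alone.

Measured so far:
- Compound 1 `COc1cccc(-c2ccc3ccc(C)nc3c2)c1`: in a functional assay on CHO cells for inhibition of metabotropic glutamate receptor 5 (Rattus norvegicus), read by FLIPR and calcium flux (on this read-out lower numbers stand for stronger inhibition and higher numbers for weaker inhibition), compound 1 gives 860 nM.
- Compound 2 `Cc1ccc2ccc(-c3cccc(O)c3)cc2n1`: in this assay compound 2 gives 19000 nM.

For the measured compounds named here, compound 1 stands lowest of the two numbers; the only other number, that of compound 2, lies a 22-fold higher number from compound 1 to compound 2 (1.34 log units; beyond the scatter) away, the change being hydrogen in place of methyl on an oxygen on an aromatic ring. The unmeasured compound 3 `COc1cc(C#N)cc(-c2ccc3ccc(C)nc3c2)c1` keeps the methoxy group and differs from compound 1 by cyano in place of hydrogen on an aromatic carbon. Going by the values given here, the one measured step concerns a different site and a different kind of change, so it does not bear on the entry of a cyano group, and nothing among the measured numbers points in a direction. Among the compounds with values here, because the single step of a 22-fold higher number from compound 1 to compound 2 (1.34 log units; beyond the scatter) is the only guide and does not apply here, the working expectation for compound 3 is a step within the scatter, a 1.4-fold lower number from compound 1 to compound 3 (0.16 log units; within the scatter). Compound 3 is estimated at 600 nM, with a range of 150 nM to 2500 nM.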

Compound 3, half-maximal inhibitory concentration: 2.4 nM
Estimate against measurement, compound 3: 250-fold (2.40 log units) above; measured number outside the range, below it.
By their numbers in this assay, from the lowest: compound 3; then compound 1; then compound 2.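

In this assay, the aromatic carbon meta to a large group and meta to a methoxy group proves highly sensitive to substitution: cyano in place of hydrogen there gives a 360-fold lower number from compound 1 to compound 3 (2.55 log units; beyond the scatter) and yields the lowest number in the series. For the compounds shown here, the earlier comparison concerned only the oxygen, where the change gave a 22-fold higher number from compound 1 to compound 2 (1.34 log units; beyond the scatter) in the opposite direction, so this is the first sign that a change on a ring carbon can lower the number at all. Nothing at hand accounts for the size of the new step.

Whether this gain is specific to cyano stays open, as the compounds shown include no amine, carboxylic acid or chlorine at this carbon. Also open, on these data alone, is whether cyano gives a comparable step when hydrogen replaces methyl on the oxygen.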